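The compounds below may be only part of what the source reports. "The series", "measured", "known", "first", "only" and "open" are said of these compounds alone.

In a functional assay on MCF7 cells (Homo sapiens) for antiproliferative activity, read by MTT assay, with a stated time of 72 h (a higher number here means a weaker inhibitor, a lower number a stronger inhibitor), compound 1 `COc1ccc(-c2ncnn2-c2cc(OC)c(OC)c(OC)c2)cc1` gives 360 nM. Compound 2 `COc1ccccc1-c1ncnn1-c1cc(OC)c(OC)c(OC)c1` is reported only as a limit of the assay, > 10000 nM. Its place on the numbers shown is thus (the limit of > 10000 nM in this assay, at which 1 of the 2 values shown sits), with no number of its own.

Compound 3 `COc1cc(-n2ncnc2-c2ccc(F)cc2)cc(OC)c1OC` differs from it at one place: 4-fluorophenyl in place of 2-methoxyphenyl on an aromatic carbon. The change is 4-fluorophenyl in place of 2-methoxyphenyl on an aromatic carbon, on the same core. Among the measured compounds shown here, one measured step bears on this, an at least 27-fold higher number from compound 1 to compound 2 (1.44 log units; beyond the scatter), which is large and beyond the scatter. It is the step of 2-methoxyphenyl in place of 4-methoxyphenyl, and compound 3 gives up that 2-methoxyphenyl group. A large step to a lower number is therefore expected in this assay, back towards compound 1 at 360 nM. For the measured compounds named here, no measured compound carries 4-fluorophenyl, so how closely it will follow 4-methoxyphenyl remains open and the range stays wide. The expected change is an at least 12-fold lower number from compound 2 to compound 3 (1.09 log units; beyond the scatter). For compound 3 the estimated value is 800 nM, with an expected range from 150 nM to 6000 nM.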

Compound 3, half-maximal inhibitory concentration: > 10000 nM
Compound 3: no number, only a limit; the forecaster's own chance of this, stated with the estimate: 15%; at least 12-fold (1.09 log units) between middle value and limit.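

Compound 3 shows that the loss at this aromatic carbon in this assay is not tied to 2-methoxyphenyl alone: with 4-fluorophenyl in place of the 4-methoxyphenyl of compound 1, the result is an at least 27-fold higher number from compound 1 to compound 3 (1.44 log units; beyond the scatter). Of the three groups shown at this place on the shared core, only 4-methoxyphenyl gives a number, while 2-methoxyphenyl and 4-fluorophenyl both give only a limit of the assay: the limit of > 10000 nM in this assay, at which 2 of the 3 values shown sit. The step between compound 2 and compound 3 cannot be read, so these two groups cannot be ranked against each other.

The compounds shown leave open how specific the requirement at this place is, since the only groups on the phenyl ring here are methoxy and fluoro, and the only one that gives a number is the methoxy group of compound 1. An ethoxy group, a methyl group or an amine in place of the fluoro of compound 3 would show whether anything other than methoxy can return a measurable value in this assay.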